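A few compounds are considered here, and "the series" means these few. Any claim that something is new, unique, unknown or untested is made for them only; others in the source may bear on it.

Working notes on a small series sharing the bicyclic hydrazone core of compound 1 `CC1(C)[C@@H]2CC[C@@]1(C)/C(=N/Nc1nc(-c3ccccc3)cs1)C2`. In an ADME assay on Vero cells (Chlorocebus sabaeus) for cytotoxicity, with a stated time of 4 days (on this read-out higher numbers stand for lower toxicity in this test and lower numbers for higher toxicity in this test), compound 1 gives 13.9 uM. Compound 2 `Cc1ccc(-c2csc(N/N=C3\C[C@H]4CC[C@]3(C)C4(C)C)n2)cc1` carries the change methyl in place of hydrogen on an aromatic carbon and in this assay compound 2 gives 13.7 uM; the step of a 1.0-fold lower number from compound 1 to compound 2 (0.01 log units; within the scatter). Compound 3 `CC1(C)[C@@H]2CC[C@@]1(C)/C(=N/N=C1/NC(=O)/C(=C/c3ccccc3)S1)C2` has a different core; how the core of compound 3 differs from that of compound 1 is not broken down here. In this assay, going by the values given here, compound 3 gives 14.5 uM, and the three numbers measured so far sit within the scatter of one another.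

Compound 4 `Cc1ccc(/C=C2\S/C(=N\N=C3/C[C@H]4CC[C@]3(C)C4(C)C)NC2=O)cc1` is not yet measured. It differs from compound 3 by methyl in place of hydrogen on an aromatic carbon, the same change as from compound 1 to compound 2. Since that change in compound 1 gave a 1.0-fold lower number from compound 1 to compound 2 (0.01 log units; within the scatter), a step of similar size is expected here, a 1.0-fold lower number from compound 3 to compound 4 (0.01 log units; within the scatter), with the added uncertainty that the core of compound 3 is not the core of compound 1. Compound 4 is therefore estimated at 14.3 uM in this assay, with a range from 8 uM to 26 uM.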

Compound 4, half-maximal toxic concentration: 121 uM
For compound 4 the middle estimate is 8.5-fold (0.93 log units) below the measured one; measured number above the stated range.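

In this assay phenyl to 4-methylphenyl on the core of compound 3 gives an 8.3-fold higher number from compound 3 to compound 4 (0.92 log units; beyond the scatter) and thus does not repeat the result of the same change on the core of compound 1: the same change on two cores in this assay, a 1.0-fold lower number (0.01 log units; within the scatter) from compound 1 to compound 2 and an 8.3-fold higher number (0.92 log units; beyond the scatter) from compound 3 to compound 4, 8.5-fold (0.93 log units) apart, beyond the scatter of two such steps.

The size of this change therefore depends on the core in these two pairs, and a step read on one of these cores cannot be carried to the other as a fixed increment. The evidence is one pair on each core, so it does not show how far this holds for other cores, and the difference between the two cores is not broken down, which leaves open what part of it goes with the gap.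

Open, from the compounds shown here alone, is whether the gap is specific to methyl or also appears with a longer chain, a methoxy group, an amine or a carboxylic acid in the same place on each core. Also open, going by these compounds, is whether either core responds in the same way when such a group sits elsewhere on the six-membered aromatic ring.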